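This account rests on a few compounds, and the source may have more. Where it says the series, first, only, none or still open, it means among the compounds named here.

Measured in an ADME assay; a higher number here means that the compound lasts longer, a lower number that the compound disappears faster:
- compound 1 `CCOc1cc(OC)ccc1C[S+]([O-])c1ncccc1C(=O)Nc1ccncc1`: 0.71 h
- compound 2 `CCOc1ccc(C[S+]([O-])c2ncccc2C(=O)Nc2ccncc2)c(OCC)c1`: 0.49 h

Among the measured compounds shown here, with only these two numbers, compound 1 has no clear rank, as the one measured comparison is a 1.4-fold lower number from compound 1 to compound 2 (0.16 log units; within the scatter). The two compounds therefore count as level in this assay.

The compound still to be measured is compound 3 `COc1ccc(C[S+]([O-])c2ncccc2C(=O)Nc2ccncc2)c(OCCF)c1`. It turns the ethoxy of compound 1 into 2-fluoroethoxy: fluoro in place of hydrogen on a saturated chain carbon, two bonds along the chain from an oxygen on an aromatic ring.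

For the measured compounds named here, only one measured step bears on this, and only loosely. Going by the values given here, in it, the one change is an added methyl, and the outcome is a 1.4-fold lower number from compound 1 to compound 2 (0.16 log units; within the scatter). Among the compounds with values here, no measured compound carries a fluoro group, so the data give no direct guide to this exchange. Within the data shown here, with that single small step as the only evidence, no shift beyond the scatter is expected in this assay.

The estimated step is a 1.2-fold lower number from compound 1 to compound 3 (0.07 log units; within the scatter). For compound 3 the expected value is 0.6 h, with an estimated range from 0.3 h to 1.2 h.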

Compound 3, half-life: 3.3 h
Estimate against measurement, compound 3: 5.5-fold (0.74 log units) below; the measured number lies above the stated range.
By their numbers in this assay, from the lowest: compounds 2 and 1 (each within the scatter of the next); then compound 3.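

In this assay, fluoro in place of hydrogen on the ethoxy chain of compound 1 gives a 4.6-fold higher number from compound 1 to compound 3 (0.67 log units; beyond the scatter) and so moves the number clearly beyond the usual scatter. The only earlier step, the added methyl, stayed small at a 1.4-fold lower number from compound 1 to compound 2 (0.16 log units; within the scatter) and was made at a different place on the molecule, so this saturated chain carbon, two bonds along the chain from an oxygen on an aromatic ring, is the first place shown where an exchange of one group changes the half-life measurably. Nothing available explains why this exchange has such an effect, and the size of the step is the only thing known about it.

The compounds shown rest on one fluoro compound, so it remains open whether the effect is particular to fluoro or would also appear with a hydroxy group or a chloro group at the same place. Going by these compounds, it is also open whether more fluorine, as in a 2,2-difluoroethoxy or 2,2,2-trifluoroethoxy group, or a longer chain such as 3-fluoropropoxy, would raise the number further, leave it level or lower it.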